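The compounds below may be only part of what the source reports. "The series", "measured", "known", "first", "only" and "open" are said of these compounds alone.

Compound 1 `CC(C)(C)n1ncc(OCc2nnc(-c3ccccc3Cl)o2)c(Cl)c1=O` carries a 2-chlorophenyl on the shared core, and in a functional assay on the whole organism for inhibition, with Mythimna separata as the target, with a stated time of 5 days (on this read-out lower numbers stand for an effect already at smaller amounts and higher numbers for an effect only at larger amounts of compound), compound 1 gives 61200 nM. Compound 2 `CC(C)(C)n1ncc(OCc2nnc(-c3ccc([N+](=O)[O-])cc3)o2)c(Cl)c1=O` differs from it only in the aryl group. In this assay compound 2 reaches only a limit of the assay, > 299000 nM, so no exact number is known for it. For the measured compounds named here, the single measured step, an at least 4.8-fold higher number from compound 1 to compound 2 (0.68 log units; beyond the scatter), is accordingly known only as a lower bound on its size, because of the limit of > 299000 nM in this assay, at which 1 of the 2 values shown sits. Compound 3 `CC(C)(C)n1ncc(OCc2nnc(-c3cc(F)c(Cl)cc3Cl)o2)c(Cl)c1=O` is the unmeasured member of the set. Its change from compound 2 is 2,4-dichloro-5-fluorophenyl in place of 4-nitrophenyl on an aromatic carbon. This change undoes the kind of swap seen in the measured step: the nitro-bearing ring leaves, and a chlorine-bearing ring, which in compound 1 went with 61200 nM, returns, now as a 2,4-dichloro-5-fluorophenyl. On that basis compound 3 is expected to come back below the limit, with an estimated step of an at least 4.9-fold lower number from compound 2 to compound 3 (0.69 log units; beyond the scatter). Compound 3 is estimated at 60000 nM in this assay, with a range from 15000 nM to 299000 nM.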

Compound 3, half-maximal effective concentration: 23100 nM
Beside the measured number, compound 3's estimate is 2.6-fold (0.41 log units) above it; low and high end bracket the measured number.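

For the compounds shown here, with compound 3, the aryl group on the shared core shows for the first time that the number in this assay can fall below that of the 2-chlorophenyl compound and not only rise from it: the change gives a 2.6-fold lower number from compound 1 to compound 3 (0.42 log units; beyond the scatter). Measured against the nitro-bearing ring the change is large, an at least 12-fold lower number from compound 2 to compound 3 (1.11 log units; beyond the scatter), but this size is only a lower bound, because compound 2 stands at a limit of the assay and not at a number: the limit of > 299000 nM in this assay, at which 1 of the 3 values shown sits. Among the three compounds, the 2,4-dichloro-5-fluorophenyl gives the lowest number, both halogen-bearing rings lie under the limit reached with the 4-nitrophenyl, and no compound shown goes against this order.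

The 2,4-dichloro-5-fluorophenyl differs from the 2-chlorophenyl by a further chlorine and a fluorine together, and the compounds shown do not separate what each contributes to the step. Also open, from the compounds shown here alone, is how this position would answer to a phenyl ring carrying a methoxy group, an amine or a carboxylic acid, or to a cyclohexyl ring in place of the phenyl ring.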